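Adding methoxymethyl to the chain of compound 3

The source may report more compounds than this note shows. Statements on the series, on what has been measured and on what is new or still open speak of the compounds shown alone.

In an ADME assay on RAW264.7 cells (Mus musculus) for cytotoxicity, read by MTT assay, with a stated time of 24 h (a lower number here means that less compound is tolerated, a higher number that more compound is tolerated), three compounds with a shared core have been measured. Compound 1 `CC/C=C\C[C@H]1C(=O)C=C[C@H]1CC(=O)OCCC` gives 35 uM. Compound 2 `CC/C=C\C[C@H]1C(=O)C=C[C@H]1CC(=O)OCCCC` gives 31 uM. Compound 3 `CC/C=C\C[C@H]1C(=O)C=C[C@H]1CC(=O)OCCOC` gives 160 uM, the highest of the three numbers, so it is the best tolerated so far.

Compound 4 `CC/C=C\C[C@H]1C(=O)C=C[C@H]1CC(=O)OCCOCCOC` differs from compound 3 in one place: methoxymethyl in place of hydrogen on a saturated chain carbon bound to an oxygen on a saturated carbon. In words, methoxymethyl stands in place of hydrogen on a saturated chain carbon bound to an oxygen on a saturated carbon.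

Going by the values given here, three measured steps bear on this change. Methyl in place of hydrogen on the chain gave a 1.1-fold lower number from compound 1 to compound 2 (0.05 log units; within the scatter). Methoxy in place of methyl gave a 4.6-fold higher number from compound 1 to compound 3 (0.66 log units; beyond the scatter), and methoxy in place of ethyl gave a 5.2-fold higher number from compound 2 to compound 3 (0.71 log units; beyond the scatter). Both methoxy steps are modest. Cut one bond further out, the new change reads methoxy to 2-methoxyethoxy, so it resembles those methoxy steps more than the methyl step. Yet three compounds are thin evidence, and none of them shows what lengthening a methoxy-ended chain does.

An upward step smaller than the methoxy steps is therefore expected in this assay, and it may not clear the scatter. The estimated change is a 1.5-fold higher number from compound 3 to compound 4 (0.18 log units; within the scatter). The expected value for compound 4 is 240 uM, within an estimated range from 120 uM to 480 uM.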

Compound 4, half-maximal toxic concentration: 161 uM
Estimate against measurement, compound 4: 1.5-fold (0.17 log units) above, within the range that was stated.
By their numbers in this assay, from the lowest: compounds 2 and 1 (each within the scatter of the next); then compounds 3 and 4 (each within the scatter of the next).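

Extending the methoxy-ended chain gave a 1.0-fold higher number from compound 3 to compound 4 (0.00 log units; within the scatter) in this assay, so methoxymethyl can stand on this saturated chain carbon bound to an oxygen on a saturated carbon with no change beyond the scatter. The higher numbers seen with compound 3 also carry over to the longer chain: 2-methoxyethoxy in place of ethyl gave a 5.2-fold higher number from compound 2 to compound 4 (0.72 log units; beyond the scatter) and 2-methoxyethoxy in place of methyl gave a 4.6-fold higher number from compound 1 to compound 4 (0.66 log units; beyond the scatter), both modest steps beyond the scatter. Across these four compounds, the two methoxy-ended chains stand above the two plain carbon chains, and no compound shown goes against this, though the added methoxymethyl brings no further gain that can be seen here.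

Going by these compounds, it remains open whether a still longer chain of the same kind would stay at this level, or whether a chain ending in an amine or a carboxylic acid would move the number in either direction. No measurement at hand accounts for the gap between the methoxy-ended chains and the plain carbon chains.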